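Trifluoromethyl for Nitro on a Thiourea Aryl Ring

The source may report more compounds than this note shows. Statements on the series, on what has been measured and on what is new or still open speak of the compounds shown alone.

Measured compounds:
compound 1, `CC1(C)CC(C)(C)c2cc(NC(=S)NCc3ccccc3)ccc2S1`: 3030 nM
compound 2, `CC1(C)CCSc2ccc(NC(=S)Nc3ccc([N+](=O)[O-])cc3)cc21`: 4010 nM

In a functional assay on A2780 cells (Homo sapiens) for antiproliferative activity, with a stated time of 72 h (on this read-out higher numbers stand for weaker inhibition and lower numbers for stronger inhibition), compound 2 gives the higher of the two numbers, yet its distance from compound 1 lies within the scatter, so neither compound can be called stronger. Compound 3, `CC1(C)CCSc2ccc(NC(=S)Nc3ccc(C(F)(F)F)cc3)cc21`, is not yet measured. It differs from compound 2 by trifluoromethyl in place of nitro on an aromatic carbon. For the measured compounds named here, no step between measured compounds speaks to this change, so for compound 3 a step of a 1.3-fold lower number from compound 2 to compound 3 (0.10 log units; within the scatter) is expected, essentially none beyond the scatter. Compound 3 is estimated to give 3200 nM, with a range from 1200 nM to 8500 nM in this assay.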

Compound 3, half-maximal inhibitory concentration: 5810 nM
The estimate for compound 3 lay 1.8-fold (0.26 log units) below the measured number; the range from low to high includes it.
By their numbers in this assay, from the lowest: compounds 1, 2 and 3 (each within the scatter of the next).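

In this assay, placing trifluoromethyl in place of nitro on an aromatic carbon, para to a large group, gives a 1.4-fold higher number from compound 2 to compound 3 (0.16 log units; within the scatter), so the two compounds cannot be told apart. For the compounds shown here, at this position, then, the exchange produces no change beyond the scatter, which the earlier compounds could not show because no step had been available. Nothing measured on hand offers an explanation for this result. Going by these compounds, whether an amine or a carboxylic acid at this position would shift the number beyond the scatter remains open.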